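Changing the aryl group on the sulfonyl sulfur

A few compounds are considered here, and "the series" means these few. Any claim that something is new, unique, unknown or untested is made for them only; others in the source may bear on it.

Of the compounds shown here, three have been tested in an assay on isolated protein for displacement of a labelled ligand from metabotropic glutamate receptor 5 (Homo sapiens), with a stated time of 60 min, tested at 1 uM; on this read-out lower numbers stand for less inhibition and higher numbers for more inhibition at the one concentration tested (going by the name of the read-out). Compound 1 `COc1ccc(S(=O)(=O)c2cnc3ccc(F)cc3c2N2CCC(C)CC2)cc1` gives 85%, compound 2 `Cc1cc(C)cc(S(=O)(=O)c2cnc3ccc(F)cc3c2N2CCC(C)CC2)c1` gives 83%, and compound 3 `Cc1ccc(S(=O)(=O)c2cnc3ccc(F)cc3c2N2CCC(C)CC2)cc1Cl` gives 91%. Compound 3 carries the highest of these three numbers, yet its gaps to the others, a number 6 percentage points higher from compound 1 to compound 3 (within the scatter) and a number 8 percentage points higher from compound 2 to compound 3 (within the scatter), both lie within the scatter, so the three cannot be ranked against one another. Compound 4 `CC1CCN(c2c(S(=O)(=O)c3cccc(C#N)c3)cnc3ccc(F)cc23)CC1` has not yet been measured. It differs from compound 3 in one place: 3-cyanophenyl in place of 3-chloro-4-methylphenyl on a sulfonyl sulfur. Every step measured so far also changes the group on the sulfonyl sulfur, and each of them, a number 2 percentage points lower from compound 1 to compound 2 (within the scatter) included, stayed within the scatter. The move to compound 4 again changes that group and nothing else, so no step beyond the scatter is expected in this assay, a number 9 percentage points lower from compound 3 to compound 4 (within the scatter). Compound 4 is therefore estimated to give 82% in this assay, with an expected range from 65% to 95%.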

Compound 4, a percentage reported as inhibition, at one concentration (the size of the read-out at that concentration, not a potency): 93%
Beside the measured number, compound 4's estimate is 11 percentage points below it; low and high end bracket the measured number.
By their numbers in this assay, from the lowest: compounds 2, 1, 3 and 4 (each within the scatter of the next).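

Compound 4 brings something new to the sulfonyl sulfur: a 3-cyanophenyl group, with a triple bond outside the ring and a hydrogen-bond acceptor, neither of which the 3-chloro-4-methylphenyl group it replaces has. In this assay this change gives a number 2 percentage points higher from compound 3 to compound 4 (within the scatter) and the same group gives a number 10 percentage points higher from compound 2 to compound 4 (within the scatter) and also a number 8 percentage points higher from compound 1 to compound 4 (within the scatter) so a nitrile at this position leaves the number as close to those of the methyl, chloro and methoxy compounds as they are to one another. No measurement here explains this result.

With all four compounds inside the scatter, the effect of the aryl group at this position remains unresolved. Also open, going by these compounds, is what an amine or a carboxylic acid on that phenyl ring, or a plain alkyl chain in place of the ring, would do.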